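The compounds below may be only part of what the source reports. "The series", "measured", "known", "first", "only" and "open" are said of these compounds alone.

Compound 1 `O=C(NCc1ccc(OCc2ccccc2)cc1)n1cccn1` and compound 2 `N#Cc1cnn(C(=O)NCc2ccc(OCc3ccccc3)cc2)c1` share one core, while compound 3 `O=C(N1CCN(C(c2ccc3ccccc3c2)c2ccc3ccccc3c2)CC1)n1cccn1` and the still-unmeasured compound 4 `N#Cc1cnn(C(=O)N2CCN(C(c3ccc4ccccc4c3)c3ccc4ccccc4c3)CC2)c1` share another. In an assay on membranes from brain for binding affinity to Monoglyceride lipase (Mus musculus), read by fluorescence, with stated times of 1 h and 30 min (a lower number here means a stronger inhibitor, a higher number a weaker inhibitor), compound 1 gives 900 nM, and compound 2 gives 100 nM. The step of a 9.0-fold lower number from compound 1 to compound 2 (0.95 log units; beyond the scatter) follows from a single structural change, (cyano in place of hydrogen on an aromatic carbon). Compound 3 gives 1800 nM in this assay; of the three measured compounds its number lies nearest to that of compound 1 and furthest from that of compound 2. How the core of compound 3 differs from the core of compound 1 is not broken down here.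

Compound 4 differs from compound 3 by cyano in place of hydrogen on an aromatic carbon. The place where the cyano enters is described in the same words for both pairs, so this is the same change that turned compound 1 into compound 2, now applied to the second core. For the measured compounds named here, on the assumption that the change carries over from one core to the other, the step from compound 3 to compound 4 is expected to be about as large as the earlier one, a 9.0-fold lower number from compound 3 to compound 4 (0.95 log units; beyond the scatter), because a 9.0-fold lower number from compound 1 to compound 2 (0.95 log units; beyond the scatter) is the only measured precedent for this change. On that basis compound 4 is expected to give roughly 200 nM in this assay, with a likely range from 70 nM to 600 nM, an estimate that rests on a single prior pair and so carries the uncertainty of whether the effect of a cyano on one core repeats on another.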

Compound 4, half-maximal inhibitory concentration: 8 nM
Compound 4: the middle estimate sits 25-fold (1.40 log units) above what was measured, and the stated range ends above it.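

Going from 1H-pyrazol-1-yl to 4-cyano-1H-pyrazol-1-yl in this assay gave a 230-fold lower number from compound 3 to compound 4 (2.35 log units; beyond the scatter), so the direction of the earlier step, a 9.0-fold lower number from compound 1 to compound 2 (0.95 log units; beyond the scatter), held on the second core. For the compounds shown here, that agreement rests on only two cores; it shows that the sign of this change carried over here, but it gives no rule for the size of the step on any further core and no reason why the size depends on the core. The size itself did not carry over, and the gap between the two steps is larger than repeated measurements would account for: the same change on two cores in this assay, a 9.0-fold lower number (0.95 log units; beyond the scatter) from compound 1 to compound 2 and a 230-fold lower number (2.35 log units; beyond the scatter) from compound 3 to compound 4, 25-fold (1.40 log units) apart, beyond the scatter of two such steps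

On these data alone, what stays open is whether another group on that aromatic carbon of the five-membered aromatic ring, such as a carboxylic acid, a primary amide or a trifluoromethyl group, would also give a larger step on the second core than on the first. As far as these compounds go, it is also open how the step would behave on a core in between the two, for instance one that keeps the piperazine-free benzyl amide of compound 1 but carries a longer chain.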